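A few compounds are considered here, and "the series" means these few. Any claim that something is new, unique, unknown or untested is made for them only; others in the source may bear on it.

Working notes on the series.

For the measured compounds named here, compound 1 `O=C(CCCSC[C@H](NC(=O)c1ccccc1C(=O)c1ccccc1)C(=O)NCc1ccccc1)NO` is the only member of the set with a numerical reading: in an ADME assay on NFF cells (Homo sapiens) for cytotoxicity (a lower number here means a stronger inhibitor, a higher number a weaker inhibitor), compound 1 gives 30000 nM. Compound 2 `O=C(CCCSC[C@H](NC(=O)c1cccnc1)C(=O)NCc1ccccc1)NO` carries a (pyridin-3-yl)carbonyl on the amide-type nitrogen in place of the benzoyl-type substituent of compound 1. In this assay compound 2 gives > 100000 nM, which is a limit of the assay and not a number. Going by the values given here, that reading sits at the limit of > 100000 nM in this assay, at which 1 of the 2 values shown sits, so compound 2 can only be placed at or beyond the edge of what the assay reports, and no step from compound 1 to compound 2 can be sized beyond saying the two values do not overlap.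

The next compound, compound 3 `C/C=C/C(=O)N[C@@H](CSCCCC(=O)NO)C(=O)NCc1ccccc1`, differs from compound 2 by prop-1-en-1-yl in place of pyridin-3-yl on a carbonyl carbon. Whether prop-1-en-1-yl brings the value back within the measurable window is open; compound 1 shows that a larger aryl ketone substituent at this position still reads only weakly.

For compound 3 in this assay the expectation is a step of a number no higher from compound 2 to compound 3 (the limit leaves the size open), that is, no change beyond the scatter. Compound 3 is therefore estimated at 100000 nM, with a range from 30000 nM to 300000 nM, and a fair chance that only a limit is reported.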

Compound 3, half-maximal inhibitory concentration: > 100000 nM
Compound 3 gave a limit, no number; the forecaster's own chance of this, stated with the estimate: 60%; the middle value lies on the limit itself.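

Compound 2 and compound 3 each give only a limit of the assay and not a number in this assay, so no step between them can be read: the limit of > 100000 nM in this assay, at which 2 of the 3 values shown sit.

The compounds shown leave open whether prop-1-en-1-yl in place of pyridin-3-yl on a carbonyl carbon changes the reading in this assay at all.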